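The compounds below may be only part of what the source reports. "The series", "measured", "known", "first", "only" and "open" are said of these compounds alone.

Measured so far:
Compound 1 `CCN1CCCC1CNC(=O)c1cc(N(C)S(C)(=O)=O)c(C)cc1OC`; in a functional assay on the whole organism for inhibition, with Mus musculus as the target (a lower number here means that less compound is needed, a higher number that more compound is needed for the effect), compound 1 gives 26.1 mg/kg.
Compound 2 `CCN1CCCC1CNC(=O)c1cc(N(C)S(C)(=O)=O)c(Cl)cc1OC`; in this assay compound 2 gives 7.7 mg/kg.
Compound 3 `CCN1CCCC1CNC(=O)c1cc(NS(C)(=O)=O)c(C)cc1OC`; in this assay compound 3 gives 35.6 mg/kg.

Compound 4 `CCN1CCCC1CNC(=O)c1cc(NS(C)(=O)=O)c(Cl)cc1OC` is not yet measured. It differs from compound 3 by chloro in place of methyl on an aromatic carbon. The same kind of change has already been measured once: compound 2 differs from compound 1 by chloro in place of methyl on an aromatic carbon, and that step gave a 3.4-fold lower number from compound 1 to compound 2 (0.53 log units; beyond the scatter). The two cores differ by hydrogen in place of methyl on a sulfonamide nitrogen, so the surroundings of the change are not identical: in compound 1 the changed carbon is ortho to a methyl(methylsulfonyl)amino group, in compound 3 ortho to a methanesulfonamido group. That core difference by itself gave a 1.4-fold higher number from compound 1 to compound 3 (0.13 log units; within the scatter), within the scatter.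

Among the measured compounds shown here, with only one earlier example, the step expected from compound 3 to compound 4 is a 3.4-fold lower number from compound 3 to compound 4 (0.53 log units; beyond the scatter), of the same size as the measured one. Compound 4 is expected near 10.5 mg/kg, with a range from 5 mg/kg to 22 mg/kg.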

Compound 4, dose for half-maximal effect: 9.1 mg/kg
Compound 4: the middle estimate sits 1.2-fold (0.06 log units) above what was measured; measured number inside the range.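

In this assay, chloro in place of methyl on an aromatic carbon carries from the core of compound 1 to the core of compound 3 with no difference beyond the scatter, the new step being a 3.9-fold lower number from compound 3 to compound 4 (0.59 log units; beyond the scatter): the same change on two cores in this assay, a 3.4-fold lower number (0.53 log units; beyond the scatter) from compound 1 to compound 2 and a 3.9-fold lower number (0.59 log units; beyond the scatter) from compound 3 to compound 4, 1.2-fold (0.06 log units) apart, within the scatter of two such steps

Hydrogen in place of methyl on a sulfonamide nitrogen also behaves alike on the methyl and chloro cores, with a 1.2-fold higher number from compound 2 to compound 4 (0.07 log units; within the scatter): the same change on two cores in this assay, a 1.4-fold higher number (0.13 log units; within the scatter) from compound 1 to compound 3 and a 1.2-fold higher number (0.07 log units; within the scatter) from compound 2 to compound 4, 1.2-fold (0.06 log units) apart, within the scatter of two such steps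

These two pairs show that the changes add up within this small set, but they do not show that this holds on cores altered elsewhere, nor why the numbers move.

Still open, on these data alone, is whether bromo or trifluoromethyl on that aromatic carbon would follow chloro. Also open, as far as these compounds go, is how a longer chain on the sulfonamide nitrogen, such as ethyl or propyl, would behave.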